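The source may report more compounds than this note shows. Statements on the series, on what has been measured and on what is new or still open speak of the compounds shown alone.

Measured compounds in a functional assay on the whole organism (strain NMRI) with Mus musculus as the target, with a stated time of 60 min, at a dose of 10 mg/kg by the intraperitoneal route; a lower number here means a weaker effect, a higher number a stronger effect of the compound at the dose given:
Compound 1 `CCCSc1nnc(Cc2ccccc2Oc2ccccc2)[nH]1` gives 139%.
Compound 2 `c1ccc(CSc2nnc(Cc3ccccc3Oc3ccccc3)[nH]2)cc1` gives 139%.
Compound 3 `CCCSc1nnc(Cc2ccc(Cl)cc2Oc2ccccc2F)[nH]1` gives 127%.

Compound 1 and compound 2 differ in one place, (phenyl in place of ethyl on a saturated chain carbon bound to a sulfur), and the step of no change at the digits printed from compound 1 to compound 2 (within the scatter). Compound 3 stands lowest of the three values; its nearest neighbour is compound 1, and the difference between the core of compound 3 and the core of compound 1 is not broken down here. Compound 4 `Fc1ccccc1Oc1cc(Cl)ccc1Cc1nnc(SCc2ccccc2)[nH]1` has not yet been measured in this assay. Going by the values given here, it differs from compound 3 by phenyl in place of ethyl on a saturated chain carbon bound to a sulfur, which is the same change as the one between compound 1 and compound 2, made on the core of compound 3 instead. Because the step of no change at the digits printed from compound 1 to compound 2 (within the scatter) lies within the scatter, the account expects the corresponding step of no change at the digits printed from compound 3 to compound 4 (within the scatter) to be small as well, resting on this single earlier instance of the change. The estimate for compound 4 in this assay is 127%, expected to lie between 112% and 142%.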

Compound 4, a percentage reported as activity, at one dose (the size of the read-out at that dose, not a potency): 169%
The estimate for compound 4 lay 42 percentage points below the measured number, outside the stated range (above it).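

In this assay, putting phenyl in place of ethyl on a saturated chain carbon bound to a sulfur, which turns propylsulfanyl into benzylsulfanyl, does not give the same result on the two cores: the same change on two cores in this assay, no change at the digits printed (within the scatter) from compound 1 to compound 2 and a number 42 percentage points higher (beyond the scatter) from compound 3 to compound 4, 42 percentage points apart, beyond the scatter of two such steps

The newer instance reads a number 42 percentage points higher from compound 3 to compound 4 (beyond the scatter), so the flat result on the first core cannot be taken as a rule for this change across the series, and its size here depends on the core that carries it. This does not show which feature of the two cores separates the results, since they differ in more than one place and that difference is not broken down, and two instances give no general trend for other cores.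

The compounds shown leave open how a longer chain, an amine or a carboxylic acid at this place on the sulfur side would read on either core. They also leave open whether the gap between the two steps would persist at other doses, as each number is a read-out at one dose and not a potency.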